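Solubility notes on the side-chain series, compound 4 pending

This account rests on a few compounds, and the source may have more. Where it says the series, first, only, none or still open, it means among the compounds named here.

compound 1, `COc1ccc(F)cc1CNCCCNc1ccnc2cc(C3CCCCC3)ccc12`: in a physicochemical assay for solubility, with a stated time of 18 h, at pH 7.4 (a higher number here means a more soluble compound, a lower number a less soluble compound), compound 1 gives 4200 nM
compound 2, `COc1cccc(Oc2ccc3c(NCCCNCc4cc(F)ccc4OC)ccnc3c2)c1`: compound 2 gives 14500 nM
compound 3, `COc1ccc(F)cc1CNCCCNc1ccnc2cc(CCc3ccccc3)ccc12`: compound 3 gives 4200 nM

Compound 3 stands level with compound 1 at the digits shown, and the two together are the lowest of the three numbers; compound 2 sits apart, with a 3.5-fold lower number from compound 2 to compound 3 (0.54 log units; beyond the scatter). Within the measured set the exchange of cyclohexyl for phenethyl, no change at the digits printed from compound 1 to compound 3 (within the scatter), left the number where it was, whereas 3-methoxyphenoxy gave a 3.5-fold higher number from compound 1 to compound 2 (0.54 log units; beyond the scatter).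

Compound 4, `COc1ccc(F)cc1CNCCCNc1ccnc2cc(Cc3ccc(C#N)cc3)ccc12`, differs from compound 3 in one place: 4-cyanophenyl in place of benzyl on a saturated chain carbon bound to an aromatic carbon. Among the compounds with values here, no measured step introduces a triple bond or a hydrogen-bond acceptor at this position; the nearest guide is the flat step no change at the digits printed from compound 1 to compound 3 (within the scatter) between two groups of comparable size on an aromatic carbon, and the only modest movement seen, a 3.5-fold higher number from compound 1 to compound 2 (0.54 log units; beyond the scatter), came from a different group. The expectation is therefore a small step, within the scatter or barely beyond it, leaning upward, a 1.4-fold higher number from compound 3 to compound 4 (0.15 log units; within the scatter). Compound 4 is estimated at 6000 nM, range 2500 nM to 14000 nM.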

Compound 4, solubility: 4200 nM
Beside the measured number, compound 4's estimate is 1.4-fold (0.15 log units) above it; low and high end bracket the measured number.
By their numbers in this assay, from the lowest: compounds 1, 3 and 4 (each within the scatter of the next); then compound 2.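

In this assay 4-cyanophenyl in place of benzyl on a saturated chain carbon bound to an aromatic carbon gives no change at the digits printed from compound 3 to compound 4 (within the scatter) so at this place a triple bond and a hydrogen-bond acceptor enter and the number stays where it was. The same holds against cyclohexyl, with no change at the digits printed from compound 1 to compound 4 (within the scatter) while the gap to the 3-methoxyphenoxy compound persists, with a 3.5-fold lower number from compound 2 to compound 4 (0.54 log units; beyond the scatter) so compounds 1, 3 and 4 read alike and compound 2 alone stands apart. Nothing measured here offers a reason for either the flat steps or the gap.

As far as these compounds go, whether an amine or a carboxylic acid in place of the nitrile would move the number as 3-methoxyphenoxy did remains open. Also open, from the compounds shown here alone, is whether a plain phenoxy would keep the number of compound 2 or a longer chain would leave the number level with compound 4.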